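This account rests on a few compounds, and the source may have more. Where it says the series, first, only, none or still open, it means among the compounds named here.

Compound 1 `O=C1CSC(c2ccccc2Cl)N1CCN1CCCCC1`, compound 2 `COc1ccc(C2SCC(=O)N2CCN2CCCCC2)cc1` and compound 3 `O=C1CSC(c2cccc(Cl)c2)N1CCN1CCCCC1` share one core and differ only in the aromatic ring that sits on a saturated ring carbon. In an ADME assay on Vero cells (Chlorocebus sabaeus) for cytotoxicity, read by neutral red uptake, tested at 49 ug/mL (on this read-out higher numbers stand for a weaker effect at the one concentration tested and lower numbers for a stronger effect), compound 1 gives 100%, compound 2 gives 100% and compound 3 gives 100%, so compound 3 stands level with both of its neighbours. For the measured compounds named here, the one step that changes a single place, no change at the digits printed from compound 1 to compound 3 (within the scatter), stays within the scatter. Compound 4 `Cc1ccc(C2SCC(=O)N2CCN2CCCCC2)cc1` differs from compound 3 by 4-methylphenyl in place of 3-chlorophenyl on a saturated ring carbon. Going by the values given here, only that measured step bears on this change, and it was flat, while compound 2 with a different ring gives the same reading, so the step of no change at the digits printed from compound 3 to compound 4 (within the scatter) is expected to show no change beyond the scatter. Compound 4 is therefore estimated at 100%, with a range from 88% to 100%.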

Compound 4, a percentage reported as activity, at one concentration (the size of the read-out at that concentration, not a potency): 100%
Compound 4: the middle estimate sits on the measured number at the digits printed; low and high end bracket the measured number.
By their numbers in this assay, from the lowest: compounds 1, 2, 3 and 4 (each within the scatter of the next).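

A ring with no chlorine, 4-methylphenyl, now joins the series on this saturated ring carbon: this assay shows no change at the digits printed from compound 3 to compound 4 (within the scatter) and no change at the digits printed from compound 1 to compound 4 (within the scatter) when either chlorophenyl is replaced. Methyl in place of methoxy on the aromatic carbon also gives no change at the digits printed from compound 2 to compound 4 (within the scatter) for this pair. All four aromatic rings therefore read alike, and none of these changes separates one compound from another. On these data alone, whether an amine or a carboxylic acid on the aromatic ring would move the reading stays open. No measurement at hand explains the flat readings.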